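The source may hold more compounds than are shown below. What is called first, only, known or untested is meant among the compounds shown, and "the series" means these compounds.

Compound 1 `CCN(CC)CCCn1c(=O)c(=Cc2ccc(F)c(F)c2)s/c1=C1\C(=O)Nc2ccc(F)cc21`: 1300 nM in a functional assay on NCI-H460 cells (Homo sapiens) for inhibition, read by MTT assay, with a stated time of 72 h; a lower number here means a stronger inhibitor, a higher number a weaker inhibitor
Compound 2 `CN(C)CCn1c(=O)c(=Cc2ccc(F)c(F)c2)s/c1=C1\C(=O)Nc2ccc(F)cc21`: 44700 nM
Compound 3 `CCN(CC)CCCn1c(=O)c(=Cc2ccccc2O)s/c1=C1\C(=O)Nc2ccc(C)cc21`: 11300 nM

Compound 2 holds the highest number of the three in this assay; compound 3 stands nearest to it, while compound 1 lies furthest, as the step of a 34-fold higher number from compound 1 to compound 2 (1.54 log units; beyond the scatter) shows. Compound 4 `CN(C)CCn1c(=O)c(=Cc2ccc(O)cc2)s/c1=C1\C(=O)Nc2ccc(F)cc21` is derived from compound 2 by 4-hydroxyphenyl in place of 3,4-difluorophenyl on a double-bonded chain carbon bound to an aromatic carbon. Within the data shown here, no measured step bears on this change: the only one-place step, from compound 1 to compound 2, alters the amine chain and leaves the aryl group untouched, and compounds 1 and 3 differ in two places at once, so their values show only that both changes together raise the number. In this assay compound 4 is therefore expected to show no step beyond the scatter, a 1.1-fold higher number from compound 2 to compound 4 (0.05 log units; within the scatter). The estimate for compound 4 is 50000 nM, with a range from 15000 nM to 150000 nM.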

Compound 4, half-maximal inhibitory concentration: 1270 nM
For compound 4 the middle estimate is 39-fold (1.60 log units) above the measured one, outside the stated range (below it).
By their numbers in this assay, from the lowest: compounds 4 and 1 (each within the scatter of the next); then compound 3; then compound 2.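

In this assay the aryl group on the double-bonded chain carbon bound to an aromatic carbon turns out to matter: with the amine chain held fixed, 4-hydroxyphenyl in place of 3,4-difluorophenyl gives a 35-fold lower number from compound 2 to compound 4 (1.55 log units; beyond the scatter). Among these compounds, the earlier compounds gave a one-place step only at the amine chain, so this is the first clean reading at this place, and it too is large. No measurement shown offers an explanation for this step.

On these data alone, what 4-methoxyphenyl or 4-fluorophenyl would give at this place remains open. So does whether the same change carries over to the longer diethylamino chain of compound 1.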